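A few compounds are considered here, and "the series" means these few. Any claim that something is new, unique, unknown or untested is made for them only; others in the source may bear on it.

Three measured compounds:

Compound 1 `COc1cc2cc(Oc3ccc(NC(=O)Nc4ccccc4)cc3)c(C)nc2cc1OC` gives 38.8% in a functional assay on RPMI-8226 cells (Homo sapiens) for inhibition, read by sulforhodamine B assay, with a stated time of 48 h, tested at 10 uM; on this read-out lower numbers stand for a stronger effect and higher numbers for a weaker effect at the one concentration tested.
Compound 2 `COc1cc2cc(Oc3ccc(NC(=O)Nc4ccc(C(F)(F)F)cc4)cc3)c(C)nc2cc1OC` gives 52.7% in this assay.
Compound 3 `COc1cc2cc(Oc3ccc(NC(=O)Nc4cccc(C(F)(F)F)c4)cc3)c(C)nc2cc1OC` gives -5.94% in this assay.

Compound 3 has the lowest of the three numbers, which on this read-out stands for the strongest effect: its nearest neighbour is compound 1, seen in the step of a number 44.7 percentage points lower from compound 1 to compound 3 (beyond the scatter), and its furthest is compound 2, seen in the step of a number 58.6 percentage points lower from compound 2 to compound 3 (beyond the scatter). Both steps were large. The remaining step, a number 13.9 percentage points higher from compound 1 to compound 2 (beyond the scatter), was modest and ran the other way.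

Compound 4 `COc1cc2cc(Oc3ccc(NC(=O)Nc4ccc(Cl)c(C(F)(F)F)c4)cc3)c(C)nc2cc1OC` differs from compound 3 by one change: chloro in place of hydrogen on an aromatic carbon. Going by the values given here, no measured step introduces or removes a chloro group, so no measured step bears directly on this change. The three measured steps show only that moving or adding a trifluoromethyl group can shift the number by a large amount in either direction, which widens the uncertainty rather than setting a direction. With nothing pointing one way, the expectation is that compound 4 stays close to compound 3, with a step of about a number 2.9 percentage points higher from compound 3 to compound 4 (within the scatter) in this assay, not clearly beyond the scatter. Compound 4 is therefore estimated at -3% in this assay, expected to fall between -35% and 35%.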

Compound 4, a percentage reported as activity, at one concentration (the size of the read-out at that concentration, not a potency): -26.4%
Compound 4: the middle estimate sits 23.4 percentage points above what was measured; measured number inside the range.
By their numbers in this assay, from the lowest: compound 4; then compound 3; then compound 1; then compound 2.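

Chloro on this ring, ortho to a trifluoromethyl group and para to a large group, gives the first measured step for this change: a number 20.5 percentage points lower from compound 3 to compound 4 (beyond the scatter) in this assay, which on this read-out stands for a stronger effect. The same ring also stands well apart from the other two aryl groups, with a number 79.1 percentage points lower from compound 2 to compound 4 (beyond the scatter) against 4-(trifluoromethyl)phenyl and a number 65.2 percentage points lower from compound 1 to compound 4 (beyond the scatter) against plain phenyl, so compound 4 has the strongest effect of the four at the one concentration tested. A 3-(trifluoromethyl)phenyl group with added chloro therefore goes further in the direction already seen for compound 3, while trifluoromethyl alone in the place that chloro holds, as in compound 2, went the other way; the data shown offer no explanation for this difference.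

The compounds shown leave open whether chloro would shift the number the same way on a ring without the trifluoromethyl group, and whether bromo, methoxy or an amine in its place would do as much. They also leave open how the order of the four would look at other concentrations, since each was tested at only one.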